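The source may hold more compounds than are shown below. What is called first, only, known or untested is meant among the compounds shown, and "the series" means these compounds.

Measured compounds:
Compound 1 `CC[C@H](C)[C@H](N)CN(C(=O)[C@@H]1C[C@H]1c1ccc(F)cc1)c1ccc(-c2ccccc2)cc1`, giving 600 nM in a functional assay for agonist activity at G protein-coupled receptor 88 (Homo sapiens), read by HTRF and cAMP accumulation; on this read-out lower numbers stand for an effect already at smaller amounts and higher numbers for an effect only at larger amounts of compound
Compound 2 `CC[C@H](C)[C@H](N)CN(C(=O)[C@@H]1C[C@H]1c1cccs1)c1ccc(-c2ccccc2)cc1`, giving 360 nM in this assay

Compound 2 shows the lowest of the two numbers in this assay; its nearest neighbour is compound 1, and the step of a 1.7-fold lower number from compound 1 to compound 2 (0.22 log units; within the scatter) lies within the scatter, so the two values cannot be put in order. Compound 3 `CC[C@H](C)[C@H](N)CN(C(=O)[C@@H]1C[C@H]1c1ccsc1)c1ccc(-c2ccccc2)cc1` differs from compound 2 in one place: thiophen-3-yl in place of thiophen-2-yl on a saturated ring carbon. The same atoms are joined differently, and the group remains a five-membered aromatic ring with one hetero atom. Among the compounds with values here, the only measured step, a 1.7-fold lower number from compound 1 to compound 2 (0.22 log units; within the scatter), exchanges another group on that saturated ring carbon and stays within the scatter; no measured step moves one thiophenyl to the other. There is therefore little ground to expect a shift beyond the scatter in this assay from compound 2 to compound 3. The estimated step, a 1.1-fold higher number from compound 2 to compound 3 (0.05 log units; within the scatter), reflects that. For compound 3 the value in this assay is expected to be 400 nM, within a range from 150 nM to 1100 nM.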

Compound 3, half-maximal effective concentration: 450 nM
Beside the measured number, compound 3's estimate is 1.1-fold (0.05 log units) below it, within the range that was stated.
By their numbers in this assay, from the lowest: compounds 2, 3 and 1 (each within the scatter of the next).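

In this assay, thiophen-3-yl in place of thiophen-2-yl on the saturated ring carbon of the three-membered ring gives a 1.3-fold higher number from compound 2 to compound 3 (0.10 log units; within the scatter), the only step shown between these two thiophenyl groups, so at this place the two ways of joining the same atoms cannot be told apart. Thiophen-3-yl in place of 4-fluorophenyl gives a 1.3-fold lower number from compound 1 to compound 3 (0.12 log units; within the scatter), so together with the earlier step, all three groups on this carbon give values that cannot be put in order. No independent measurement is at hand that bears on why these values lie so close together.

All three groups shown here are aromatic rings, so it stays open whether an amine, a carboxylic acid or a longer chain such as n-butyl on this saturated ring carbon would give a value beyond the scatter. From the compounds shown here alone, it also stays open how a pyridinyl ring would compare, and whether thiophen-2-yl and thiophen-3-yl would remain this close with another group elsewhere on the shared core.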